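From Phenyl to Pyrrolidinyl-Pyridine: an Expected Potency Gain

The source may hold more compounds than are shown below. What is called first, only, known or untested is meant among the compounds shown, and "the series" means these compounds.

Three measured compounds share one core and differ only in the aromatic group attached to it. Compound 3 `O=C(O)Cc1sc(C(c2ccc(F)cc2)c2ccc(F)cc2)nc1-c1ccccc1` carries a plain phenyl. In an in vitro functional assay on HEK285-7 cells for antagonist activity at prostaglandin D2 receptor 2 (Homo sapiens), read by BRET and beta-arrestin recruitment (a higher number here means a weaker inhibitor, a lower number a stronger inhibitor), compound 3 gives 240 nM, the second highest of the three numbers. Compound 1 `N#Cc1cc(-c2nc(C(c3ccc(F)cc3)c3ccc(F)cc3)sc2CC(=O)O)ccc1F`, with 3-cyano-4-fluorophenyl, gives 520 nM in this assay, and a 2.2-fold lower number from compound 1 to compound 3 (0.34 log units; beyond the scatter). Compound 2 `O=C(O)Cc1sc(C(c2ccc(F)cc2)c2ccc(F)cc2)nc1-c1ccnc(F)c1`, with 2-fluoropyridin-4-yl, gives 4.7 nM in this assay; a 51-fold higher number from compound 2 to compound 3 (1.71 log units; beyond the scatter), so compound 2 is clearly the strongest inhibitor of the three.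

Going by the values given here, compound 4 `O=C(O)Cc1sc(C(c2ccc(F)cc2)c2ccc(F)cc2)nc1-c1ccnc(N2CCCC2)c1` has not yet been measured. 2-(pyrrolidin-1-yl)pyridin-4-yl in place of phenyl on an aromatic carbon The step that bears on this is the one between compound 2 and compound 3, where a pyridine ring in place of phenyl moved the number a great deal. Among the compounds with values here, compound 4 keeps the pyridine but carries a pyrrolidin-1-yl in place of the fluorine of compound 2, a change with no measured precedent here. For compound 4 a large drop is therefore expected, a 24-fold lower number from compound 3 to compound 4 (1.38 log units; beyond the scatter), with the exact size uncertain. Compound 4 is estimated at 10 nM, within 2 nM to 60 nM.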

Compound 4, half-maximal inhibitory concentration: > 100000 nM
Compound 4 gave a limit, no number; the forecaster's own chance of this, stated with the estimate: 0%; at least 10000-fold (4.00 log units) between middle value and limit.
By their numbers in this assay, from the lowest: compound 2; then compound 3; then compound 1. At a limit, above all of these: compound 4.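

Compound 4 gives a limit and not a number: the limit of > 100000 nM in this assay, at which 1 of the 4 values shown sits. Pyrrolidin-1-yl in place of the fluoro of the 2-fluoropyridin-4-yl group gives an at least 21000-fold higher number from compound 2 to compound 4 (4.32 log units; beyond the scatter), so the pyridine ring alone does not bring strong inhibition, and the group it carries can remove it entirely. The same change also falls behind the plain phenyl, with an at least 410-fold higher number from compound 3 to compound 4 (2.61 log units; beyond the scatter), and behind the 3-cyano-4-fluorophenyl, with an at least 190-fold higher number from compound 1 to compound 4 (2.28 log units; beyond the scatter), which makes compound 4 the weakest inhibitor of the four.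

From the compounds shown here alone, whether the loss belongs to the pyrrolidine ring itself or to any nitrogen-linked group in that place remains open. A plain amine, a dimethylamino or a methoxy group on the pyridine would show how much of the strong inhibition of compound 2 survives replacing the fluoro.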